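The compounds below may be only part of what the source reports. "The series", "measured", "known", "first", "only" and "open" are said of these compounds alone.

Measured in a functional assay on HL-60 cells (Homo sapiens) for antiproliferative activity, read by sulforhodamine B assay, with a stated time of 72 h; a lower number here means a stronger inhibitor, a higher number a weaker inhibitor:
- compound 1 `N#Cc1ccc(NC(=S)N/N=C/c2ccc3ccccc3n2)cc1`: 4660 nM
- compound 2 `FC(F)(F)c1ccc(NC(=S)N/N=C/c2ccc3ccccc3n2)cc1`: 34900 nM

Compound 2 has the higher of the two numbers, which makes it the weaker inhibitor of the pair. Compound 3 `S=C(N/N=C/c1ccc2ccccc2n1)Nc1ccccc1` differs from it in one place: hydrogen in place of trifluoromethyl on an aromatic carbon. In words, this is hydrogen in place of trifluoromethyl on an aromatic carbon. For the measured compounds named here, only one measured step bears on this change. It alters the same carbon and is modest but beyond the scatter: a 7.5-fold higher number from compound 1 to compound 2 (0.87 log units; beyond the scatter). Going by the values given here, no compound with hydrogen there has been measured, so the guess is rough: removing trifluoromethyl should lower the number by a similar amount. The expected step is a 3.9-fold lower number from compound 2 to compound 3 (0.59 log units; beyond the scatter). For compound 3 the estimated value is 9000 nM, with a range of 2500 nM to 32000 nM.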

Compound 3, half-maximal inhibitory concentration: 9130 nM
The estimate for compound 3 lay 1.0-fold (0.01 log units) below the measured number; measured number inside the range.
By their numbers in this assay, from the lowest: compounds 1 and 3 (each within the scatter of the next); then compound 2.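

In this assay the hydrogen compound gives this carbon a reference point: taking away trifluoromethyl gives a 3.8-fold lower number from compound 2 to compound 3 (0.58 log units; beyond the scatter) and so marks trifluoromethyl as the group that stands apart here. Putting hydrogen in place of cyano gives a 2.0-fold higher number from compound 1 to compound 3 (0.29 log units; within the scatter) and so leaves these two groups indistinguishable. Nothing available explains why trifluoromethyl differs from the other two groups. The compounds shown leave open how an amine, a carboxylic acid or a methoxy group on this carbon would compare with hydrogen. They also leave open whether any group here can give a clearly lower number than hydrogen.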